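Amide series at the rat adenosine receptor: two measured, one pending

The source may report more compounds than this note shows. Statements on the series, on what has been measured and on what is new or still open speak of the compounds shown alone.

Measured so far:
compound 1 `O=C(Nc1nccn2cc(-c3ccccc3)nc12)c1ccccc1` gives 2%
compound 2 `COc1ccc(C(=O)Nc2nc(-c3ccccc3)cn3cc(-c4ccccc4)nc23)cc1` gives 1%

Both compounds were tested in an assay on cells for displacement of a labelled ligand from adenosine receptor A3 (Rattus norvegicus), read by scintillation counting, with a stated time of 120 min, tested at 1 uM; a lower number here means less inhibition, a higher number more inhibition at the concentration tested (going by the name of the read-out). In this assay compound 1 gives 2%, and in this assay compound 2 gives 1%. Compound 2 holds the lowest of the two numbers, but its nearest neighbour is compound 1, only a single percentage point higher, so the two values sit within the usual scatter and no order between them can be read. Both compounds sit near the bottom of the read-out scale, which says essentially no displacement at the concentration tested.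

Compound 3 `O=C(Nc1nc(-c2ccccc2)cn2cc(-c3ccccc3)nc12)c1cccnc1` has not yet been measured in this assay. It differs from compound 2 by pyridin-3-yl in place of 4-methoxyphenyl on a carbonyl carbon. Among the compounds with values here, no step between measured compounds exists to calibrate this change. Given that both measured amides lie at the floor of the scale, the step from compound 2 to compound 3 is expected to be none beyond the scatter, meaning a number 2 percentage points higher from compound 2 to compound 3 (within the scatter) in this assay. Compound 3 is therefore estimated to give 3%, with an expected range from -7% to 14%.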

Compound 3, a percentage reported as inhibition, at one concentration (the size of the read-out at that concentration, not a potency): 2%
The estimate for compound 3 lay 1 percentage points above the measured number, within the range that was stated.
By their numbers in this assay, from the lowest: compounds 2, 1 and 3 (each within the scatter of the next).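

In this assay, within the data shown here, pyridin-3-yl in place of 4-methoxyphenyl on a carbonyl carbon gives a number 1 percentage points higher from compound 2 to compound 3 (within the scatter), the first step that isolates a single place. Replacing an aromatic ring of carbon only with one holding a hetero atom, and removing the methoxy group with it, does not separate the two compounds, although both lie near the bottom of the scale, where a real effect of this change could stay hidden. No measurement is at hand that would explain this result.

From the compounds shown here alone, it remains open whether any group on this carbonyl carbon can raise the number clearly above the floor of the scale, for instance a piperidine, a carboxylic acid or a longer alkyl chain in place of the aromatic ring. Also open, going by these compounds, is whether the floor belongs to the amide link itself, which replacing the carbonyl with a methylene group or the whole amide with a free amine on the shared core would test.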